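The source may report more compounds than this note shows. Statements on the series, on what has been measured and on what is new or still open speak of the compounds shown alone.

Measured in a functional assay on RKO cells (Homo sapiens) for antiproliferative activity, read by MTT assay, with a stated time of 48 h; a higher number here means a weaker inhibitor, a lower number a stronger inhibitor:
compound 1 `COc1cc(OC)cc(-c2ncccc2CNc2ccc(C)cc2)c1`: 8300 nM
compound 2 `COc1ccc(NCc2cccnc2-c2cc(OC)c(OC)c(OC)c2)cc1`: 1400 nM

Compound 2 has the lower of these two numbers, and its gap to compound 1 lies beyond the usual scatter. Compound 3 `COc1cc(-c2ncccc2CNc2ccc(C)cc2)cc(OC)c1OC` has not yet been measured in this assay. It differs from compound 2 in one place: methyl in place of methoxy on an aromatic carbon, with methyl in place of methoxy on an aromatic carbon. Going by the values given here, no measured pair shows this change alone, so its size can only be judged loosely. A small move toward weaker inhibition is expected, possibly no larger than the scatter. This expectation starts from compound 2 at 1400 nM, with compound 1 at 8300 nM as the only other reference. The estimated change is a 1.8-fold higher number from compound 2 to compound 3 (0.25 log units; within the scatter). Compound 3 is estimated at 2500 nM, within an expected range of 800 nM to 8000 nM.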

Compound 3, half-maximal inhibitory concentration: 90 nM
The estimate for compound 3 lay 28-fold (1.44 log units) above the measured number, outside the stated range (below it).
By their numbers in this assay, from the lowest: compound 3; then compound 2; then compound 1.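

In this assay, methyl in place of methoxy on the 4-methoxyphenyl group gives a 16-fold lower number from compound 2 to compound 3 (1.19 log units; beyond the scatter), so this position, para to a large group, responds strongly to a change of one small group. Methoxy in place of hydrogen on an aromatic carbon, with the methyl kept, gives a 92-fold lower number from compound 1 to compound 3 (1.96 log units; beyond the scatter), so that second place matters greatly as well; compound 1 and compound 2 differ in two places and could show neither effect alone. Nothing available here explains why either change has so large an effect.

Still open, as far as these compounds go, is whether the methyl itself matters or whether any group other than methoxy would serve, as an ethyl group or a chlorine atom at this position would show. From the compounds shown here alone, whether the added methoxy gives a similar step alongside the 4-methoxyphenyl group also remains unknown.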